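A few compounds are considered here, and "the series" means these few. Any claim that something is new, unique, unknown or untested is made for them only; others in the source may bear on it.

Measured compounds:
compound 1 `CN1CCN(c2ccc(Nc3ncc4nc(Sc5ccccc5)n(C5CCOCC5)c4n3)cc2)CC1` gives 42.6 nM
compound 2 `CN1CCN(c2ccc(Nc3ncc4nc(SCc5cccnc5)n(C5CCCC5)c4n3)cc2)CC1` gives 517 nM
compound 3 `CN1CCN(c2ccc(Nc3ncc4nc([S+]([O-])c5ccccc5)n(C5CCCC5)c4n3)cc2)CC1` gives 64.7 nM

The numbers come from a functional assay on HCC827 cells (Homo sapiens) for antiproliferative activity, read by MTT assay, with a stated time of 72 h; a lower number here means a stronger inhibitor, a higher number a weaker inhibitor. Compound 1 has the lowest number of the three; compound 3 is closest to it, within the scatter, while compound 2 is furthest, a gap beyond the scatter. Compound 4 `CN1CCN(c2ccc(Nc3ncc4nc([S+]([O-])c5ccccc5)n(C5CCOCC5)c4n3)cc2)CC1` has not yet been measured. Compared with compound 1, the change is a group of 8 heavy atoms (6 carbon, 1 oxygen, 1 sulfur; one six-membered aromatic ring of carbon only) in place of a group of 7 heavy atoms (6 carbon, 1 sulfur; one six-membered aromatic ring of carbon only), on an aromatic carbon.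

For the measured compounds named here, only one measured step touches this place on the core: an 8.0-fold lower number from compound 2 to compound 3 (0.90 log units; beyond the scatter). That step, however, also swaps one six-membered aromatic ring with 1 hetero atom for one six-membered aromatic ring of carbon only, so it does not isolate the entry of the oxygen on the sulfur. Compound 1 and compound 3 differ in both the sulfur group and the ring on the nitrogen, and their numbers sit within the scatter of each other, which suggests the sulfur change by itself does little here. The expected step of a 1.2-fold higher number from compound 1 to compound 4 (0.07 log units; within the scatter) is therefore none beyond the scatter. Compound 4 is estimated at 50 nM, with a range of 20 nM to 130 nM.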

Compound 4, half-maximal inhibitory concentration: 411 nM
Compound 4: the middle estimate sits 8.2-fold (0.91 log units) below what was measured, and the stated range ends below it.
By their numbers in this assay, from the lowest: compounds 1 and 3 (each within the scatter of the next); then compounds 4 and 2 (each within the scatter of the next).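

In this assay, for the compounds shown here, the change on the aromatic carbon, read for the first time with oxan-4-yl held fixed, is far from silent: placing an oxygen on the sulfur of phenylsulfanyl gives a 9.6-fold higher number from compound 1 to compound 4 (0.98 log units; beyond the scatter). With that oxygen-bearing group held fixed, oxan-4-yl in place of cyclopentyl on the aromatic nitrogen gives a 6.4-fold higher number from compound 3 to compound 4 (0.80 log units; beyond the scatter), so each of these two changes registers beyond the scatter, and the closeness of the numbers for compound 1 and compound 3 cannot be taken to mean that the sulfur change does little. No measurement shown here accounts for either step.

Still open, from the compounds shown here alone, is whether the oxygen on the sulfur has the same size of effect with cyclopentyl on the nitrogen. Going by these compounds, how a sulfonyl or an amine would fare on that aromatic carbon also remains open.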